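The source may report more compounds than this note shows. Statements on the series, on what has been measured and on what is new or still open speak of the compounds shown alone.

Compound 1 `Cc1[nH]c2ccc(Br)cc2c(=O)c1Br`: > 31500 nM (a limit)
Compound 2 `Cc1[nH]c2ccc(Cl)cc2c(=O)c1Br`: 21700 nM

For the measured compounds named here, in an ADME assay on J774 cells (Mus musculus) for cytotoxicity (on this read-out lower numbers stand for an effect already at smaller amounts and higher numbers for an effect only at larger amounts of compound), compound 2 gives 21700 nM, the only true number so far. Compound 1 gives > 31500 nM, which is a limit of the assay and not a number.

Compound 3 `Cc1[nH]c2ccc(F)cc2c(=O)c1Br` differs from compound 2 in a single place (fluoro in place of chloro on an aromatic carbon). It carries fluoro in place of chloro on an aromatic carbon of a six-membered aromatic ring of carbon only, and the rest of the core stays the same.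

Going by the values given here, one measured step bears on this change, a similar exchange of one group for another at the same place, chloro in place of bromo: an at least 1.4-fold lower number from compound 1 to compound 2 (0.16 log units; that floor lies within the scatter). That step has only a floor and no true size, so it gives weak guidance on size and direction. On this single comparison, no step beyond the scatter is expected in this assay. The expected step is a 1.2-fold higher number from compound 2 to compound 3 (0.06 log units; within the scatter). For compound 3 the estimated value is 25000 nM, with an expected range from 12000 nM to 45000 nM.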

Compound 3, half-maximal effective concentration in the J774 assay: > 39100 nM
Compound 3 gave a limit, no number (the forecaster's own chance of this, stated with the estimate: 40%); middle value at least 1.5-fold (0.19 log units) from the limit.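

In the J774 assay the exchange of chloro for fluoro on this aromatic carbon gives an at least 1.8-fold higher number from compound 2 to compound 3 (0.25 log units; that floor lies within the scatter), so even the smallest step the data allow stays within the usual scatter. In the J774 assay compound 3 gives > 39100 nM, which is a limit of the assay and not a number. In a physicochemical assay for lipophilicity, at pH 7.4 (on this read-out lower numbers stand for lower lipophilicity and higher numbers for higher lipophilicity), compound 2 gives 2.02 and compound 3 gives 1.61. For the compounds shown here, what the earlier compounds did not show is that this same exchange also moves a second measured property, lipophilicity, by more than the scatter: the measured distribution coefficient of compound 2, 2.02, and of compound 3, 1.61, a number 0.41 log units lower (beyond the scatter).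

On these data alone, the step between compound 1 and compound 3 cannot be read, and with so few compounds it stays open whether the effect on the cells and lipophilicity move together at all. The compounds shown carry only bromo, chloro and fluoro at this place, so it also stays open how either read-out would respond to a group of another kind there, such as a methoxy, a nitrile or an amine.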